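Compound 3 to compound 4: pentyloxy for cyclopentylamino

The source may hold more compounds than are shown below. What is called first, only, known or untested is meant among the compounds shown, and "the series" means these compounds.

Of the compounds shown here, three on the shared core have been read in an ADME assay on HFF cells (Homo sapiens) for cytotoxicity, with a stated time of 8 days; on this read-out lower numbers stand for higher toxicity in this test and higher numbers for lower toxicity in this test. Compound 1 `C=CCOc1nc(N)nc2c1ncn2/C=C1/CC1(CO)CO` gives > 300000 nM, which is a limit. Compound 2 `CCCSc1nc(N)nc2c1ncn2/C=C1/CC1(CO)CO` gives > 300000 nM, also a limit. Compound 3 `Nc1nc(NC2CCCC2)c2ncn(/C=C3/CC3(CO)CO)c2n1` gives > 300000 nM, again a limit, so it has no number of its own. All three stand at one place on the scale: the limit of > 300000 nM in this assay, at which 3 of the 3 values shown sit.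

Compound 4 `CCCCCOc1nc(N)nc2c1ncn2/C=C1/CC1(CO)CO`, not yet measured, carries pentyloxy in place of cyclopentylamino on an aromatic carbon.

The measured steps that bear on this change are exchanges on the same aromatic carbon. They are a step that the two limits leave unreadable from compound 1 to compound 3, a step that the two limits leave unreadable from compound 2 to compound 3 and a step that the two limits leave unreadable from compound 1 to compound 2. None of them has a readable size, so they show no change in a number and give no direction. Among the measured compounds, allyloxy in compound 1 is the group closest in name to pentyloxy, and compound 1 remains at the limit of > 300000 nM.

On this basis, no step beyond the scatter is expected in this assay, although three limits cannot rule out a lower reading. The expected step is a number no higher from compound 3 to compound 4 (the limit leaves the size open). The estimate for compound 4 is 300000 nM, with an expected range of 120000 nM to 400000 nM.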

Compound 4, half-maximal cytotoxic concentration: 259000 nM
Compound 4: the middle estimate sits 1.2-fold (0.06 log units) above what was measured; the measured number falls inside the stated range.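

Notes on the aromatic carbon that carries the exchanged group: in this assay compound 4, with pentyloxy, gives the first reading in the series that is a number and not a limit, while the exchanges among allyloxy, propylsulfanyl and cyclopentylamino cannot be read, and the other compounds stay at one place: the limit of > 300000 nM in this assay, at which 3 of the 4 values shown sit. Against those compounds, the new reading gives only floors (an at least 1.1-fold lower number from compound 3 to compound 4 (0.06 log units; that floor lies within the scatter)) and (an at least 1.1-fold lower number from compound 2 to compound 4 (0.06 log units; that floor lies within the scatter)) and (an at least 1.1-fold lower number from compound 1 to compound 4 (0.06 log units; that floor lies within the scatter)), and each floor lies within the scatter. The exchange of cyclopentylamino, with its five-membered ring and hydrogen-bond donor, for open-chain pentyloxy, and of vinyl for butyl on the chain of compound 1, therefore shows no readable step beyond the scatter at this position.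

From the compounds shown here alone, the true size of all three steps stays open, since the partner in each is a limit with no number of its own. Also open, going by these compounds, is how a longer chain such as octyloxy, or benzylamino on the same aromatic carbon, would read in this assay on the shared core.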